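The compounds below may be only part of what the source reports. "The series", "measured", "known", "first", "only" and "open" are said of these compounds alone.

Measured in a functional assay on A549 cells (Homo sapiens) for antiproliferative activity, read by luminescence and CellTiter-Glo, with a stated time of 48 h; on this read-out lower numbers stand for stronger inhibition and higher numbers for weaker inhibition:
- Compound 1 `COc1ccc(/C=C/[C@@H]2CC=CC(=O)O2)cc1`: > 100000 nM
- Compound 2 `O=C1C=CC[C@@H](/C=C/c2ccc([N+](=O)[O-])cc2)O1`: > 100000 nM
- Compound 3 `O=C1C=CC[C@H](/C=C/c2ccc(F)cc2)O1`: 10200 nM

Among the measured compounds shown here, compound 3 gives 10200 nM, the only true number in this small set. The other two compounds stand at the limit of > 100000 nM in this assay, at which 2 of the 3 values shown sit, and such a limit is not a number.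

Compound 4 `O=C1C=CC[C@@H](/C=C/c2ccc(F)cc2)O1` has the same atoms and bonds as compound 3, and the two differ only in configuration as drawn: the two compounds have the same atoms and bonds and differ only in configuration as drawn: 1 of 2 stereo elements differ; a stereocentre at a saturated ring carbon is drawn R in compound 3 and S in compound 4.

For the measured compounds named here, the one measured step, a step that the two limits leave unreadable from compound 1 to compound 2, involves a different kind of change and gives no size. Going by the values given here, no measured step therefore sizes a change of configuration, and no direction can be favoured in this assay.

The estimated step, a 1.4-fold higher number from compound 3 to compound 4 (0.14 log units; within the scatter), is expected to stay within the scatter, though with wide uncertainty. For compound 4 the expected value is 14000 nM, with an estimated range of 3000 nM to 70000 nM.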

Compound 4, half-maximal inhibitory concentration: > 100000 nM
Compound 4: a limit, no number; the forecaster's own chance of this, stated with the estimate: 25%; middle value at least 7.1-fold (0.85 log units) from the limit.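

In this assay, among the compounds shown here, the configuration at this saturated ring carbon proves to matter, a kind of change the earlier compounds could not size: the change gives an at least 9.8-fold higher number from compound 3 to compound 4 (0.99 log units; beyond the scatter). This gap can be tied to that one stereocentre alone because nothing else in the structures changes: the fact that compounds 3 and 4 differ only in the configuration as drawn. The steps from compound 1 and compound 2 to compound 4 cannot be read, since both ends of each are limits: the limit of > 100000 nM in this assay, at which 3 of the 4 values shown sit.

Of the compounds shown, only the fluoro compound carries the configuration of compound 3. As far as these compounds go, how a methoxy, a nitro or an amine on that aromatic carbon would fare in this configuration stays open.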